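The compounds below may be only part of what the source reports. "The series", "measured", "known", "first", "only" and "open" are said of these compounds alone.

Of the compounds shown here, three built on one shared core have been tested in a functional assay on PC-3 cells (Homo sapiens) for inhibition, read by MTT assay, with a stated time of 72 h; on this read-out lower numbers stand for stronger inhibition and higher numbers for weaker inhibition. Compound 1 `CCc1cccc(NC(=O)CSc2nc(Nc3ccccc3)c3ccccc3n2)c1` gives 11000 nM. Compound 2 `O=C(CSc1nc(Nc2ccccc2)c2ccccc2n1)Nc1ccc(F)cc1` gives 9560 nM in this assay. Compound 3 `C=CC(=O)Nc1cccc(NC(=O)CSc2nc(Nc3cccc(Cl)c3)c3ccccc3n2)c1` gives 12300 nM in this assay. The number for compound 3 is the highest of the three, yet its gaps to compound 1 and to compound 2 both lie within the scatter, so the three compounds cannot be told apart on what has been measured.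

Among the compounds with values here, the only measured step between close neighbours, a 1.2-fold lower number from compound 1 to compound 2 (0.06 log units; within the scatter), exchanged one group for another on an amide-type nitrogen and stayed within the scatter.

Compound 4 `C=CC(=O)Nc1cccc(NC(=O)CSc2nc(Nc3ccc(CC)cc3)c3ccccc3n2)c1` has not yet been measured. It differs from compound 3 in one place: 4-ethylphenyl in place of 3-chlorophenyl on a nitrogen on an aromatic ring. Within the data shown here, the exchange sits on a nitrogen on an aromatic ring, a different place from the one altered between compound 1 and compound 2, so the one known step bears on it only loosely; still, that step shows an exchange of one phenyl group for another leaving the number in place. No step beyond the scatter is therefore expected, and the estimate amounts to a 1.0-fold lower number from compound 3 to compound 4 (0.01 log units; within the scatter). For compound 4 the expected value is 12000 nM, with a range from 6000 nM to 25000 nM.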

Compound 4, half-maximal inhibitory concentration: 24300 nM
Estimate against measurement, compound 4: 2.0-fold (0.31 log units) below; the measured number falls inside the stated range.
By their numbers in this assay, from the lowest: compounds 2, 1, 3 and 4 (each within the scatter of the next, the first and the last beyond it).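

Within the data shown here, this is the first measured change on the nitrogen on an aromatic ring, as the earlier step touched only the amide-type nitrogen, and a 2.0-fold higher number from compound 3 to compound 4 (0.30 log units; within the scatter) is as large as a difference can be while still counting as scatter, so the two compounds cannot be told apart. The exchange of 3-chlorophenyl for 4-ethylphenyl replaces chlorine with a two-carbon ethyl group and also alters where that group sits on the phenyl ring, so this single step covers two changes at once and cannot assign any share of the difference to either one. Nothing shown gives a measured reason for the size of this step.

The two changes could be separated by a pair such as 4-chlorophenyl and 3-ethylphenyl on this same nitrogen, with the rest of compound 3 kept in place. On these data alone, it also remains open how this position responds to a phenyl ring carrying an amine or a carboxylic acid, since only chlorine and ethyl appear on that ring among the compounds with this side chain.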